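The source may hold more compounds than are shown below. What is called first, only, known or untested is meant among the compounds shown, and "the series" means these compounds.

Among the compounds with values here, compound 3, `CSc1ccc(C2=C(c3ccc(OCC4CO4)cc3)C(=O)N3CCCC3C2)cc1`, gives the lowest of the three numbers measured so far in a functional assay on M14 cells (Homo sapiens) for cytotoxicity; on this read-out higher numbers stand for weaker inhibition of growth and lower numbers for stronger inhibition of growth: compound 3 gives 90 nM. Compound 1, `COc1ccc(C2=C(c3ccc(SC)cc3)CC3CCCN3C2=O)cc1Br`, gives 3000 nM in this assay, and compound 2, `COc1ccc(C2=C(c3ccc(SC)cc3)CC3CCCN3C2=O)cc1`, gives 4000 nM. Within the data shown here, the one large step among the measured compounds is a 44-fold lower number from compound 2 to compound 3 (1.65 log units; beyond the scatter), whereas a 1.3-fold higher number from compound 1 to compound 2 (0.12 log units; within the scatter).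

Compound 4, `CSc1ccc(C2=C(c3ccc(F)cc3)C(=O)N3CCCC3C2)cc1`, differs from compound 3 in one place: fluoro in place of (oxiran-2-yl)methoxy on an aromatic carbon. Among the measured compounds shown here, no measured pair shows fluoro against (oxiran-2-yl)methoxy directly, so the nearest guide is the step from compound 2 to compound 3, in which the oxiran-2-yl group entering on the saturated chain carbon went with the large fall in the number. Compound 4 loses that group, and the methoxy-bearing chain with it, so the expectation is that most of that gain is lost and the number rises back toward those of compound 1 and compound 2. The step from compound 1 to compound 2 suggests that small changes on the other aromatic ring matter little, but it says nothing about fluoro on this ring.

Compound 4 is therefore expected to give about 3000 nM in this assay, with a range from 700 nM to 12000 nM, which would be a step of a 33-fold higher number from compound 3 to compound 4 (1.52 log units; beyond the scatter).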

Compound 4, concentration for 50% growth inhibition: 600 nM
For compound 4 the middle estimate is 5.0-fold (0.70 log units) above the measured one; measured number outside the range, below it.
By their numbers in this assay, from the lowest: compound 3; then compound 4; then compounds 1 and 2 (each within the scatter of the next).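

Read against the other compounds in this assay, fluoro on this aromatic carbon, para to a large group, behaves neither like (oxiran-2-yl)methoxy nor like methoxy. Losing (oxiran-2-yl)methoxy costs part of the gain, with a 6.7-fold higher number from compound 3 to compound 4 (0.82 log units; beyond the scatter), yet fluoro in place of methoxy still gives a 6.7-fold lower number from compound 2 to compound 4 (0.82 log units; beyond the scatter), so this position separates three groups into three levels and a single fluorine atom accounts for part of the distance that earlier looked tied to the oxiran-2-yl group. The same direction holds where 4-fluorophenyl replaces 3-bromo-4-methoxyphenyl, with a 5.0-fold lower number from compound 1 to compound 4 (0.70 log units; beyond the scatter), so the compound carrying bromo does not go against this reading.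

No measurement here bears on what lies behind these differences at this position. The compounds shown leave open whether the three-membered ring of (oxiran-2-yl)methoxy is needed for the remaining gap to fluoro, which a plain propoxy chain at the same place would test, and whether chloro, an amine or a carboxylic acid there would fall with fluoro, with methoxy or elsewhere.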